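Removing a Methoxy Group from a Selenocyanate Carbamate

The compounds below may be only part of what the source reports. "The series", "measured", "known", "first", "only" and "open" are said of these compounds alone.

Of the compounds shown here, three have been measured in a functional assay on HTB-54 cells (Homo sapiens) for cytotoxicity, read by MTT assay, with a stated time of 72 h; on this read-out higher numbers stand for weaker inhibition of growth and lower numbers for stronger inhibition of growth. Compound 1 `COc1ccc(OC(=O)Nc2ccc([Se]C#N)cc2)cc1` gives 48500 nM. Compound 2 `O=C(Nc1ccc([Se][Se]c2ccc(NC(=O)OCc3ccccc3)cc2)cc1)OCc1ccccc1` gives 50900 nM, and compound 3 `O=C(Nc1ccc([Se][Se]c2ccc(NC(=O)OCc3ccc([N+](=O)[O-])cc3)cc2)cc1)OCc1ccc([N+](=O)[O-])cc1` gives 55600 nM. The number for compound 1 is the lowest of the three, but the numbers of compound 2 and compound 3 both lie within the usual scatter of it, so the three compounds cannot be put in any order of growth inhibition on this evidence; they behave alike.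

Compound 4 `N#C[Se]c1ccc(NC(=O)Oc2ccccc2)cc1` has not yet been measured. It differs from compound 1 in a single place: hydrogen in place of methoxy on an aromatic carbon. For the measured compounds named here, none of the measured compounds differ from one another in just one spot, so there is no measured step of this kind to lean on. The change itself is small, the loss of a methoxy group from the aromatic ring with nothing but a hydrogen taking its place, and the three measured compounds, which differ far more from one another, still give numbers within the scatter. The step is therefore expected to be a 1.0-fold higher number from compound 1 to compound 4 (0.01 log units; within the scatter), which is no step beyond the scatter and no clear direction. Compound 4 is estimated to give 50000 nM in this assay, within a range from 25000 nM to 100000 nM.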

Compound 4, concentration for total growth inhibition: 50200 nM
The estimate for compound 4 lay 1.0-fold (0.00 log units) below the measured number, within the range that was stated.
By their numbers in this assay, from the lowest: compounds 1, 4, 2 and 3 (each within the scatter of the next).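

For the compounds shown here, this is the first step that changes a single place, so the effect of one group can now be read on its own. In this assay, putting hydrogen in place of methoxy on an aromatic carbon, para to a large group, gives a 1.0-fold higher number from compound 1 to compound 4 (0.01 log units; within the scatter), so at this position the two groups cannot be told apart. The methoxy group can therefore go, taking its hydrogen-bond acceptor with it, and the number stays within the scatter, although nothing measured here says why this position shows so little response.

Only methoxy and hydrogen have been compared at this position, so an amine, a carboxylic acid or a longer alkoxy chain in the same place could still give a number beyond the scatter. The step also says nothing about the rest of the core of compound 1, and what happens when the selenocyanate group is replaced by another group cannot be read from any single-place pair shown.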